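Cytotoxicity notes: substituent on the triazole benzylic carbon

The source may report more compounds than this note shows. Statements on the series, on what has been measured and on what is new or still open speak of the compounds shown alone.

Measured so far:
compound 1 `Cc1cc(C)c(Oc2cc(Nc3ccc(C#N)cc3)ncc2C(=O)NCc2cn(Cc3ccccc3[N+](=O)[O-])nn2)c(C)c1` — > 212000 nM
compound 2 `COC(=O)Cn1cc(CNC(=O)c2cnc(Nc3ccc(C#N)cc3)cc2Oc2c(C)cc(C)cc2C)nn1` — 13800 nM

In an ADME assay on MT4 cells (Homo sapiens) for cytotoxicity, read by MTT assay, with a stated time of 5 days (a higher number here means that more compound is tolerated, a lower number that less compound is tolerated), compound 1 gives > 212000 nM, which is a limit of the assay rather than a number. Within the data shown here, compound 2 gives 13800 nM, the only actual number in the set. The other value, that of compound 1, is a limit (the limit of > 212000 nM in this assay, at which 1 of the 2 values shown sits). Among the measured compounds shown here, the one measured step, an at least 15-fold lower number from compound 1 to compound 2 (1.18 log units; beyond the scatter), is the sole guide available.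

Compound 3 `Cc1cc(C)c(Oc2cc(Nc3ccc(C#N)cc3)ncc2C(=O)NCc2cn(Cc3cccc(F)c3)nn2)c(C)c1` differs from compound 2 by 3-fluorophenyl in place of methoxycarbonyl on a saturated chain carbon bound to an aromatic nitrogen. This puts an aromatic ring back at the place where compound 1 carries 2-nitrophenyl and compound 2 carries methoxycarbonyl. The measured step of an at least 15-fold lower number from compound 1 to compound 2 (1.18 log units; beyond the scatter) runs in the opposite direction to this change. A higher number, of comparable size, is therefore expected: a 7.2-fold higher number from compound 2 to compound 3 (0.86 log units; beyond the scatter), with a fair chance that compound 3 again only reaches a limit. The estimate for compound 3 is 100000 nM, range 25000 nM to 250000 nM.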

Compound 3, half-maximal cytotoxic concentration: >= 204000 nM
Compound 3: only a limit was reported; the forecaster's own chance of this, stated with the estimate: 45%; at least 2.0-fold (0.30 log units) between middle value and limit.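

Replacing methoxycarbonyl with 3-fluorophenyl on a saturated chain carbon bound to an aromatic nitrogen gives, in this assay, an at least 14-fold higher number from compound 2 to compound 3 (1.16 log units; beyond the scatter). Compound 3 gives a limit and not a number: the limit of >= 204000 nM in this assay, at which 1 of the 3 values shown sits. Among these compounds, with 2-nitrophenyl in compound 1 and 3-fluorophenyl in compound 3 both giving limits, the only actual number in the set belongs to the methoxycarbonyl of compound 2, so the lower tolerance is tied so far to that one group and not to a single aromatic substituent, while the step between compound 1 and compound 3 cannot be read.

On these data alone, it remains open whether methoxycarbonyl is unusual here or whether non-aromatic groups in general give lower numbers; a carboxylic acid or an amine at this place would test that. As far as these compounds go, how much compound is actually tolerated for compound 1 and compound 3 also remains unknown.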